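Removing the Benzyl Group From an Amine Nitrogen

The compounds below may be only part of what the source reports. "The series", "measured", "known", "first", "only" and "open" are said of these compounds alone.

Going by the values given here, compound 2 `O=C(NS(=O)(=O)CCNCc1ccccc1)c1ccc(Nc2nc(NC3(c4ccc(Cl)cc4)CC3)nc(OCC(F)(F)F)n2)cc1` holds the higher of the two numbers measured so far in a physicochemical assay for permeability, using PAMPA, at pH 7.4; on this read-out lower numbers stand for lower permeability and higher numbers for higher permeability: compound 2 gives 49 nm/s, whereas compound 1 `CC(C)C(=O)NCCS(=O)(=O)NC(=O)c1ccc(Nc2nc(NC3(c4ccc(Cl)cc4)CC3)nc(OCC(F)(F)F)n2)cc1` gives 13 nm/s. Compound 3 `NCCS(=O)(=O)NC(=O)c1ccc(Nc2nc(NC3(c4ccc(Cl)cc4)CC3)nc(OCC(F)(F)F)n2)cc1` is reached from compound 2 by hydrogen in place of benzyl on an amine nitrogen. Among the compounds with values here, no measured pair covers exactly this change. Within the data shown here, the one step that bears on it is a 3.8-fold higher number from compound 1 to compound 2 (0.58 log units; beyond the scatter), where the group on that same amine nitrogen was swapped and the number rose. Compound 3 goes further in the opposite direction, paring the group on the nitrogen back to a single hydrogen atom, so in this assay a step toward a lower number is expected, probably of similar size to the measured one and beyond the scatter, though with real uncertainty about how far it falls. Compound 3 is therefore estimated at 10 nm/s, with a range of 3 nm/s to 30 nm/s. That estimate amounts to an expected 4.9-fold lower number from compound 2 to compound 3 (0.69 log units; beyond the scatter).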

Compound 3, apparent permeability: 153 nm/s
Beside the measured number, compound 3's estimate is 15-fold (1.18 log units) below it, and the stated range ends below it.
By their numbers in this assay, from the lowest: compound 1; then compound 2; then compound 3.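

In this assay, hydrogen in place of benzyl on the amine nitrogen gives a 3.1-fold higher number from compound 2 to compound 3 (0.49 log units; beyond the scatter) and hydrogen in place of isopropylcarbonyl gives a 12-fold higher number from compound 1 to compound 3 (1.07 log units; beyond the scatter) at the same place. Going by these compounds alone, the earlier compounds offered only one swap of one substituent for another, whereas the three compounds now form a single order at this nitrogen: isopropylcarbonyl lowest, benzyl in the middle and hydrogen highest, with every gap beyond the usual scatter. Neither substituent raises the number above that of the unsubstituted amine, so the rise seen with benzyl is only a partial recovery of what the amine of compound 3 shows, and nothing available here accounts for this order.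

The compounds shown leave open where a small alkyl group such as methyl, a dimethylamino group or a simple acetyl group would fall in this order, and so whether the order depends on the carbonyl, on the phenyl ring or on the mere presence of a substituent. They also leave open how the number would respond to a longer chain between the sulfonyl group and the amine, or to a carboxylic acid in place of the amine.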